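A few compounds are considered here, and "the series" means these few. Any claim that something is new, unique, unknown or untested is made for them only; others in the source may bear on it.

Measured compounds:
compound 1 `CCCC(=O)Nc1c(C(O)(C(F)(F)F)C(F)(F)F)ccc2ccccc12` — 708 nM
compound 2 `O=C(Nc1c(C(O)(C(F)(F)F)C(F)(F)F)ccc2ccccc12)c1cnco1` — 302 nM

In a functional assay (Sus scrofa) with sulfonylurea receptors; K-ATP channels (Homo sapiens) as the target (on this read-out higher numbers stand for an effect only at larger amounts of compound and lower numbers for an effect already at smaller amounts), compound 1 gives 708 nM, and compound 2 gives 302 nM, the lowest of the two numbers. For the measured compounds named here, the one measured step, a 2.3-fold lower number from compound 1 to compound 2 (0.37 log units; beyond the scatter), arises from exchanging the propyl chain for an aromatic heterocycle on the carbonyl carbon, and it is the only change so far that bears on the carbonyl substituent.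

Compound 3 `O=C(Nc1c(C(O)(C(F)(F)F)C(F)(F)F)ccc2ccccc12)c1cccnc1` has not been measured. It differs from compound 2 by pyridin-3-yl in place of 1,3-oxazol-5-yl on a carbonyl carbon. Both the leaving and the entering group are aromatic heterocycles attached to the same carbonyl carbon, so the measured step, which swaps a chain for a heterocycle, bears only loosely on this one. With no aryl-to-aryl comparison at hand, compound 3 is expected to sit close to compound 2 in this assay, with a step of a 1.0-fold lower number from compound 2 to compound 3 (0.00 log units; within the scatter) that does not clearly pass beyond the scatter in either direction. The estimate for compound 3 is 300 nM, with a range from 110 nM to 850 nM.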

Compound 3, half-maximal effective concentration: 617 nM
Estimate against measurement, compound 3: 2.1-fold (0.31 log units) below, within the range that was stated.
By their numbers in this assay, from the lowest: compound 2; then compounds 3 and 1 (each within the scatter of the next).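

In this assay the result shows that the choice of ring at this place, a carbonyl carbon whose other neighbour is an amide-type nitrogen, still counts once the substituent is an aromatic heterocycle: pyridin-3-yl in place of 1,3-oxazol-5-yl gives a step beyond the scatter (a 2.0-fold higher number from compound 2 to compound 3 (0.31 log units; beyond the scatter)). It also shows that an aromatic heterocycle on the carbonyl carbon does not by itself go with a lower number than propyl, since the exchange of propyl for 1,3-oxazol-5-yl passes beyond the scatter (a 2.3-fold lower number from compound 1 to compound 2 (0.37 log units; beyond the scatter)), whereas the exchange of propyl for pyridin-3-yl stays within it (a 1.1-fold lower number from compound 1 to compound 3 (0.06 log units; within the scatter)). No measurement at hand gives a reason for this difference between the two rings.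

The compounds shown leave open whether the lower number of compound 2 goes with the five-membered ring or with its second hetero atom, as the two rings differ in both, and a plain phenyl ring or a 1,3-thiazol-5-yl group on the same carbonyl carbon would bear on that question. They also leave open how a longer chain or an amine-bearing substituent would behave at this place.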